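Allyloxy to methoxy: from compound 2 to compound 4

The source may report more compounds than this note shows. Statements on the series, on what has been measured and on what is new or still open speak of the compounds shown alone.

In a functional assay on RAW264.7 cells (Mus musculus) for inhibition, read by Griess assay, with stated times of 1 h and 24 h (a lower number here means a stronger inhibitor, a higher number a weaker inhibitor), compound 1 (`CC(C)COc1ccccc1C1CC(=O)c2ccccc2O1`) gives 36700 nM and compound 2 (`C=CCOc1ccccc1C1CC(=O)c2ccccc2O1`) gives 37800 nM while compound 3 (`O=C1CC(c2ccccc2OCc2ccccc2)Oc2ccccc21`) gives 18900 nM on the same read-out. Compound 2 sits within the scatter of both others, with a 1.0-fold higher number from compound 1 to compound 2 (0.01 log units; within the scatter) and a 2.0-fold lower number from compound 2 to compound 3 (0.30 log units; within the scatter) as its steps. Compound 4 (`COc1ccccc1C1CC(=O)c2ccccc2O1`) turns allyloxy to methoxy: hydrogen in place of vinyl on a saturated chain carbon bound to an oxygen on an aromatic ring in words, hydrogen in place of vinyl on a saturated chain carbon bound to an oxygen on an aromatic ring. Exchanges at this place have all stayed within the scatter, including a 1.9-fold lower number from compound 1 to compound 3 (0.29 log units; within the scatter) as the third step, though none replaced the end group with hydrogen. The expected change is a 1.1-fold higher number from compound 2 to compound 4 (0.05 log units; within the scatter) and so none beyond the scatter. For compound 4 in this assay the estimated value is 42000 nM (expected range 20000 nM to 85000 nM).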

Compound 4, half-maximal inhibitory concentration: 47300 nM
Compound 4: middle estimate off by 1.1-fold (0.05 log units), on the low side; low and high end bracket the measured number.
By their numbers in this assay, from the lowest: compounds 3, 1, 2 and 4 (each within the scatter of the next, the first and the last beyond it).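

In this assay, within the data shown here, hydrogen in place of phenyl gives the first step at this position that lies beyond the scatter (a 2.5-fold higher number from compound 3 to compound 4 (0.40 log units; beyond the scatter)). Hydrogen in place of vinyl (a 1.3-fold higher number from compound 2 to compound 4 (0.10 log units; within the scatter)) and hydrogen in place of isopropyl (a 1.3-fold higher number from compound 1 to compound 4 (0.11 log units; within the scatter)) both stay within it, so among these end groups only phenyl separates from hydrogen. No evidence at hand accounts for this difference.

The compounds shown leave open how a longer chain ending in phenyl would read here, and how an amine or a carboxylic acid at this end would read.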